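Replacing the Carbamate on the Core by an Aryl Amine

A few compounds are considered here, and "the series" means these few. Any claim that something is new, unique, unknown or untested is made for them only; others in the source may bear on it.

Compound 1 `CC(C)COC(=O)Nc1nc2ccc(NC(=O)c3c(Cl)cccc3Cl)cc2s1`: 0.0035 ug/mL
Compound 2 `O=C(Nc1nc2ccc(NC(=O)c3c(Cl)cccc3Cl)cc2s1)OCc1ccccc1`: 0.018 ug/mL
Compound 3 `O=C(Nc1nc2ccc(NC(=O)c3c(Cl)cccc3Cl)cc2s1)Oc1ccccc1`: 1.1 ug/mL

The three compounds were tested in a functional assay on WI-38 VA13 cells (Homo sapiens) for cytotoxicity; on this read-out lower numbers stand for an effect already at smaller amounts and higher numbers for an effect only at larger amounts of compound. Compound 3 gives the highest number of the three: a 61-fold higher number from compound 2 to compound 3 (1.79 log units; beyond the scatter) and a 310-fold higher number from compound 1 to compound 3 (2.50 log units; beyond the scatter). Compound 4 `COc1cccc(Nc2nc3ccc(NC(=O)c4c(Cl)cccc4Cl)cc3s2)c1` has not been measured yet. It differs from compound 3 in this way: 3-methoxyphenyl in place of phenoxycarbonyl on a nitrogen on an aromatic ring. Among the compounds with values here, no measured step makes a change of this kind; the known steps only exchange the group on the oxygen of the carbamate, and both exchanges that placed a phenyl there raised the number. As far as these compounds go, the direction for compound 4 therefore stays open. Compound 4 is expected to lie near compound 3 with a wide spread, a 2.2-fold lower number from compound 3 to compound 4 (0.34 log units; beyond the scatter). The estimate for compound 4 is 0.5 ug/mL, between 0.03 ug/mL and 8 ug/mL.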

Compound 4, half-maximal effective concentration: > 7.2 ug/mL
Compound 4 ended at the assay's limit; the forecaster's own chance of this, stated with the estimate: 10%; middle value at least 14-fold (1.15 log units) from the limit.
By their numbers in this assay, from the lowest: compound 1; then compound 2; then compound 3. At a limit, above all of these: compound 4.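

The value of compound 4 is a limit of this assay, not a number: the limit of > 7.2 ug/mL in this assay, at which 1 of the 4 values shown sits. The earlier compounds shown here only exchanged the group on the carbamate oxygen, whereas here the whole carbamate on this nitrogen gives way to 3-methoxyphenyl, with an at least 6.5-fold higher number from compound 3 to compound 4 (0.81 log units; beyond the scatter), an at least 400-fold higher number from compound 2 to compound 4 (2.60 log units; beyond the scatter) and an at least 2000-fold higher number from compound 1 to compound 4 (3.31 log units; beyond the scatter). Within the data shown here, all three carbamates therefore show their effect at smaller amounts than this aryl amine, including compound 3, the one with the highest number among them.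

As far as these compounds go, how far compound 4 lies past its limit remains open. So does whether a smaller group on this nitrogen, such as acetyl or methyl, would keep the effect of the carbamates.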